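Swapping imidazolyl for thiophenyl on a salicylic acid core

This account rests on a few compounds, and the source may have more. Where it says the series, first, only, none or still open, it means among the compounds named here.

Of the compounds shown here, three sharing a salicylic acid core have been measured in a physicochemical assay for solubility, in phosphate buffer, at pH 7; a lower number here means a less soluble compound, a higher number a more soluble compound. Compound 1 `O=C(O)c1ccc(-c2cscn2)cc1O` gives 8700 ug/mL, and compound 2 `O=C(O)c1cc(-c2ncccn2)ccc1O` gives 6000 ug/mL. Compound 3 `O=C(O)c1cc(-c2c[nH]cn2)ccc1O` gives 1100 ug/mL, the lowest of the three numbers, and its distance from both compound 1 and compound 2 lies beyond the usual scatter of this assay.

The next compound, compound 4 `O=C(O)c1cc(-c2cccs2)ccc1O`, differs from compound 3 in one place: thiophen-2-yl in place of 1H-imidazol-4-yl on an aromatic carbon. The group that leaves carries one hydrogen-bond donor, the group that enters carries none, and the position on the core is unchanged.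

Within the data shown here, no measured pair here shows a step of this exact kind, so the expectation rests on where compound 3 sits. The step is expected to be modest and downward, a 1.6-fold lower number from compound 3 to compound 4 (0.20 log units; within the scatter), perhaps no larger than the scatter itself. Compound 4 is therefore estimated at 700 ug/mL in this assay, with a plausible range from 150 ug/mL to 3000 ug/mL.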

Compound 4, solubility: 7000 ug/mL
Beside the measured number, compound 4's estimate is 10-fold (1.00 log units) below it; the measured number lies above the stated range.
By their numbers in this assay, from the lowest: compound 3; then compounds 2, 4 and 1 (each within the scatter of the next).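

In this assay, among these compounds, the change from 1H-imidazol-4-yl to thiophen-2-yl gives a 6.4-fold higher number from compound 3 to compound 4 (0.80 log units; beyond the scatter), the first step in this set between compounds that differ in one place. It shows that at this position, meta to a carboxy group and para to a hydroxy group, exchanging one five-membered aromatic ring for another can shift the read-out beyond the scatter. The step comes with the loss of a hydrogen-bond donor and a change in ring atoms, and this single pair cannot separate the two; nothing measured here accounts for the step.

A methyl group on the imidazole ring nitrogen would test whether that hydrogen matters or the ring as a whole does. Going by these compounds, how a phenyl ring or an aminomethyl group would read at this position also remains open.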